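The compounds below may be only part of what the source reports. "The series", "measured", "known", "first", "only" and "open" are said of these compounds alone.

Compound 1 `COc1ccc(-c2cnc(NC(=O)C3CCCCC3)n2C)cc1`: in a toxicity assay on THP-1 cells (Homo sapiens) for inhibition (a lower number here means that less compound is tolerated, a higher number that more compound is tolerated), a limit of the assay, > 100000 nM.
Compound 2 `COc1ccc(-c2cnc(NC(=O)c3cccc(OC)c3)n2C)cc1`: in this assay a limit of the assay, > 100000 nM.
Compound 3 `COc1ccc(-c2cnc(NC(=O)c3ccco3)n2C)cc1`: in this assay a limit of the assay, > 100000 nM.

Compound 3 thus stands where every value in the set stands, at the limit of > 100000 nM in this assay, at which 3 of the 3 values shown sit. The step to compound 4 `COc1ccc(-c2cnc(NC(=O)C3CCOCC3)n2C)cc1` is oxan-4-yl in place of furan-2-yl on a carbonyl carbon. Within the data shown here, the steps that bear on it, a step that the two limits leave unreadable from compound 1 to compound 3 and a step that the two limits leave unreadable from compound 2 to compound 3, are both unreadable, as is a step that the two limits leave unreadable from compound 1 to compound 2; the cyclohexyl of compound 1 is the nearest precedent for a saturated ring on this carbonyl carbon. No step beyond the scatter is therefore expected in this assay, and compound 4 is expected to remain at the limit, estimated at 150000 nM (range 50000 nM to 500000 nM), the expected step being a step that the limit leaves unreadable from compound 3 to compound 4.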

Compound 4, half-maximal cytotoxic concentration: > 100000 nM
Compound 4: no number, only a limit (the forecaster's own chance of this, stated with the estimate: 85%); the middle value is on the limit's open side.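

No step can be read among compound 1, compound 2, compound 3 and compound 4 in this assay, since all sit at a limit of the assay: the limit of > 100000 nM in this assay, at which 4 of the 4 values shown sit.

The compounds shown leave open how far any of the four lies from that limit, and whether any group on the carbonyl carbon changes tolerance in this assay.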